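The source may hold more compounds than are shown below. What is called first, only, known or untested is meant among the compounds shown, and "the series" means these compounds.

Of the compounds shown here, three sharing one core have been measured, and they differ only in the group attached to a saturated chain carbon bound to an amide-type nitrogen in a ring. In a functional assay on MCF7 cells (Homo sapiens) for inhibition, read by MTT assay, with a stated time of 48 h, tested at 2 uM (a higher number here means more inhibition at the concentration tested (going by the name of the read-out), a lower number less inhibition), compound 1 `Cc1noc(C)c1-c1ccc2c(c1)C(c1ccccc1)N(Cc1ncc(-c3ccccc3)o1)C(=O)N2C` gives 34%. Compound 2 `Cc1noc(C)c1-c1ccc2c(c1)C(c1ccccc1)N(Cc1nnc(-c3ccccc3)s1)C(=O)N2C` gives 35.7%, and compound 3 `Cc1noc(C)c1-c1ccc2c(c1)C(c1ccccc1)N(Cc1nc(-c3ccc(F)cc3)cs1)C(=O)N2C` gives 27.4%. Compound 3 carries the lowest of the three numbers, yet its gaps to the other two are within the scatter of this assay, so no ordering can be drawn from them.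

Compound 4 `Cc1noc(C)c1-c1ccc2c(c1)C(c1ccccc1)N(Cc1csc(-c3ccc(F)cc3)n1)C(=O)N2C` is built from the same atoms as compound 3, joined differently: 2-(4-fluorophenyl)-1,3-thiazol-4-yl in place of 4-(4-fluorophenyl)-1,3-thiazol-2-yl on a saturated chain carbon bound to an amide-type nitrogen in a ring. Within the data shown here, the steps that bear on this change are the earlier swaps of this group, a number 1.7 percentage points higher from compound 1 to compound 2 (within the scatter), a number 6.6 percentage points lower from compound 1 to compound 3 (within the scatter) and a number 8.3 percentage points lower from compound 2 to compound 3 (within the scatter), all of which stayed within the scatter. Rearranging the same group is therefore expected to produce no step beyond the scatter, and the expected step is a number 2.6 percentage points higher from compound 3 to compound 4 (within the scatter). Compound 4 is estimated to give 30%, with a range from 18% to 42%.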

Compound 4, a percentage reported as inhibition, at one concentration (the size of the read-out at that concentration, not a potency): 37.9%
Estimate against measurement, compound 4: 7.9 percentage points below; low and high end bracket the measured number.
By their numbers in this assay, from the lowest: compounds 3, 1, 2 and 4 (each within the scatter of the next, the first and the last beyond it).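

Rearranging the same atoms within this group can matter at this position: in this assay, 2-(4-fluorophenyl)-1,3-thiazol-4-yl in place of 4-(4-fluorophenyl)-1,3-thiazol-2-yl gives a number 10.5 percentage points higher from compound 3 to compound 4 (beyond the scatter) and so produces the first step in this set beyond the scatter, though only a modest one. Among these compounds, the other new steps, a number 2.2 percentage points higher from compound 2 to compound 4 (within the scatter) and a number 3.9 percentage points higher from compound 1 to compound 4 (within the scatter), stay within the scatter, so compound 4 cannot be ranked against compound 1 or compound 2, and only the pair of thiazole isomers separates. Nothing measured here explains why joining the ring differently changes the reading.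

From the compounds shown here alone, it remains open whether the same rearrangement would give a similar step with a plain phenyl group in place of the 4-fluorophenyl group. Going by these compounds, it is also open how either thiazole arrangement would read with a morpholine or a carboxylic acid on the thiazole ring instead.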